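The source may report more compounds than this note shows. Statements on the series, on what has been measured and on what is new or still open speak of the compounds shown alone.

Compound 1 `[O-][S+]1CC(Nc2nonc2/C(=N/O)Nc2ccc(F)c(Br)c2)C1` in an assay on HeLa cells for inhibition of Indoleamine 2,3-dioxygenase 1 (Homo sapiens), read by spectrophotometry, with a stated time of 24 h (on this read-out higher numbers stand for an effect only at larger amounts of compound and lower numbers for an effect already at smaller amounts), gives 79 nM. Among the three measured compounds it holds the second highest number: compound 2 `N=S1(=O)CC(Nc2nonc2/C(=N/O)Nc2ccc(F)c(Br)c2)C1` gives 53 nM, and compound 3 `O=S(=O)(CCNc1nonc1/C(=N/O)Nc1ccc(F)c(Br)c1)N1CCC1` gives 143 nM. The step of a 1.5-fold lower number from compound 1 to compound 2 (0.17 log units; within the scatter) and the step of a 1.8-fold higher number from compound 1 to compound 3 (0.26 log units; within the scatter) both stay within the scatter. Compound 4 `NS(=O)(=O)CCCNc1nonc1/C(=N/O)Nc1ccc(F)c(Br)c1` differs from compound 1 in one place: a group of 7 heavy atoms (3 carbon, 1 nitrogen, 2 oxygen, 1 sulfur; no ring) in place of a group of 5 heavy atoms (3 carbon, 1 oxygen, 1 sulfur; one four-membered non-aromatic ring with 1 hetero atom), on a nitrogen on an aromatic ring. Both measured steps from compound 1 bear on this change, since each also replaces the same four-membered non-aromatic ring group on the nitrogen on the aromatic ring, and neither moved the number beyond the scatter. Compound 4 is therefore expected to show a 1.3-fold higher number from compound 1 to compound 4 (0.10 log units; within the scatter), a step not beyond the scatter. The estimate for compound 4 is 100 nM, within 50 nM to 200 nM.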

Compound 4, half-maximal effective concentration: 15 nM
The estimate for compound 4 lay 6.7-fold (0.82 log units) above the measured number, and the stated range ends above it.
By their numbers in this assay, from the lowest: compound 4; then compounds 2, 1 and 3 (each within the scatter of the next, the first and the last beyond it).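

In this assay, 3-sulfamoylpropyl on this nitrogen gives the first step from compound 1 that lies beyond the scatter (a 5.3-fold lower number from compound 1 to compound 4 (0.72 log units; beyond the scatter)), so this position can move the number after all. It also stands apart from the other two groups (a 3.5-fold lower number from compound 2 to compound 4 (0.55 log units; beyond the scatter); a 9.5-fold lower number from compound 3 to compound 4 (0.98 log units; beyond the scatter)), and compound 3 shows that a sulfonyl on a chain does not by itself give so low a number. No measurement shown gives a cause for these steps. As far as these compounds go, whether a longer chain, or a carboxylic acid in place of the sulfamoyl, would keep the number this low remains open.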